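A Methylsulfonylpiperazine Tail on the Shared Core

The compounds below may be only part of what the source reports. "The series", "measured", "known", "first", "only" and "open" are said of these compounds alone.

Compound 1 `COc1cc(N)c(Cl)cc1C(=O)NC1CCN(CCCCCCCCO)CC1` in a functional assay on HEK293 cells for activation of 5-hydroxytryptamine receptor 4 (Homo sapiens), read by cAMP accumulation; a lower number here means a smaller maximal response, a higher number a larger maximal response: > 100%, a limit of the assay.
Compound 2 `COc1cc(N)c(Cl)cc1C(=O)NC1CCN(CCN2CCCCC2)CC1` in this assay: > 100%, a limit of the assay.
Compound 3 `COc1cc(N)c(Cl)cc1C(=O)NC1CCN(CCCCCN2CCCCC2)CC1` in this assay: > 100%, a limit of the assay.

Compound 3 stands only at a limit in this assay, and the two other values shown are limits as well, so that all three sit at the limit of > 100% in this assay, at which 3 of the 3 values shown sit. The steps among them are therefore unreadable: a step that the two limits leave unreadable from compound 1 to compound 2, a step that the two limits leave unreadable from compound 1 to compound 3 and a step that the two limits leave unreadable from compound 2 to compound 3 give no size and no direction.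

Compound 4 `COc1cc(N)c(Cl)cc1C(=O)NC1CCN(CCN2CCN(S(C)(=O)=O)CC2)CC1` differs from compound 3 in one place: 4-(methylsulfonyl)piperazin-1-yl in place of 3-(piperidin-1-yl)propyl on a saturated chain carbon, two bonds along the chain from an amine nitrogen in a ring. Going by the values given here, the measured steps that bear on it, those from compound 1 and compound 2 to compound 3, were all left unreadable by the limits, so no size of step in this assay can be derived from them. The expectation for compound 4 is that the maximal response stays near the region the three measured compounds occupy, with the estimated step of a number no higher from compound 3 to compound 4 (the limit leaves the size open) assumed to be within the scatter. Compound 4 is estimated at 100% in this assay, between 80% and 115%.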

Compound 4, intrinsic activity: the largest response reached, in percent of the reference agonist's: 97%
Compound 4: middle estimate off by 3 percentage points, on the high side, and the stated range covers the measured number.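

In this assay, compound 4 is the only one shown that gives a number rather than a limit, so 4-(methylsulfonyl)piperazin-1-yl on a saturated chain carbon, two bonds along the chain from an amine nitrogen in a ring, offers the first readable value at this position. The change reads as a number at least 3 percentage points lower from compound 3 to compound 4 (that floor lies within the scatter), as a number at least 3 percentage points lower from compound 2 to compound 4 (that floor lies within the scatter) and as a number at least 3 percentage points lower from compound 1 to compound 4 (that floor lies within the scatter), and each of these is only a floor, so the true steps may be larger. The other three compounds give no number to set against it: the limit of > 100% in this assay, at which 3 of the 4 values shown sit.

On these data alone, the steps among compound 1, compound 2 and compound 3 cannot be read, and how far any of them lies past its limit stays unknown. Also open, as far as these compounds go, is how the maximal response would go with an acetyl group in place of the methylsulfonyl on the piperazine, or with a longer chain leading to that ring.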